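The source may hold more compounds than are shown below. What is called first, only, known or untested is meant among the compounds shown, and "the series" means these compounds.

Measured so far:
compound 1, `C=C(C(=O)c1ccc(OC)cc1)C(OC(=O)c1ccccc1)c1ccc([N+](=O)[O-])cc1`: in a functional assay on A549 cells (Homo sapiens) for inhibition, read by XTT assay, with a stated time of 48 h (a higher number here means a weaker inhibitor, a lower number a stronger inhibitor), compound 1 gives 66600 nM.
compound 2, `C=C(C/C(=C\c1ccc(OC(=O)c2ccccc2)cc1)C(=O)c1ccc(OC)cc1)C(=O)c1ccc(OC)cc1`: in this assay compound 2 gives > 100000 nM, which is a limit of the assay and not a number.

Compound 2 thus stands at the limit of > 100000 nM in this assay, at which 1 of the 2 values shown sits; no number is known for it. Going by the values given here, compound 1 and compound 2 share no single-point change, so what their two values show is only that compound 1 has a number and compound 2 does not.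

Next up is compound 3, `C=C(C/C(=C\c1ccc(C)cc1)C(=O)c1ccc(OC)cc1)C(=O)c1ccc(OC)cc1`, not yet tested in this assay. It differs from compound 2 in one place: methyl in place of benzoyloxy on an aromatic carbon. Among the compounds with values here, no measured step covers such a change in this set. Starting from a limit, neither direction can be read off the pair; the working expectation is a step within or close to the scatter, with compound 3 remaining weak. Compound 3 is therefore estimated at 90000 nM, with a range of 30000 nM to 300000 nM, and a fair chance that only a limit is reported again. This estimate means an expected step of an at least 1.1-fold lower number from compound 2 to compound 3 (0.04 log units; that floor lies within the scatter).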

Compound 3, half-maximal inhibitory concentration: 43800 nM
For compound 3 the middle estimate is 2.1-fold (0.31 log units) above the measured one; the measured number falls inside the stated range.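

In this assay, methyl in place of benzoyloxy on the aromatic carbon para to a large group gives an at least 2.2-fold lower number from compound 2 to compound 3 (0.35 log units; beyond the scatter), the first single-point comparison available in this series. The benzoyloxy group, with its six-membered aromatic ring and its carbonyl, is therefore not required at this position for a measurable value, and compound 3 gives 43800 nM with only a single methyl carbon there, though this is still a high number in this assay. The step is a lower bound and not a measured size, because compound 2 has only a limit and no number: the limit of > 100000 nM in this assay, at which 1 of the 3 values shown sits.

The comparison rests on a single pair, so it does not show whether the change depends on the size of the group or on something else about it, and a hydroxyl, a methoxy, an amine or a longer chain at the same position would be needed to separate these readings. It also leaves open whether the shared core can reach much lower numbers in this assay with any group at this position, or whether changes elsewhere on the core would be needed.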